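Swapping the cinnamamide aryl group in a trimethoxybenzophenone series

The source may hold more compounds than are shown below. What is called first, only, known or untested is meant among the compounds shown, and "the series" means these compounds.

Measured so far in a functional assay on PC-3 cells (Homo sapiens) for cytotoxicity, read by MTT assay, with a stated time of 72 h; a lower number here means a stronger inhibitor, a higher number a weaker inhibitor:
Compound 1, `COc1ccc(/C=C/C(=O)Nc2cc(C(=O)c3cc(OC)c(OC)c(OC)c3)ccc2OC)cc1`, gives 11100 nM.
Compound 2, `COc1cccc(/C=C/C(=O)Nc2cc(C(=O)c3cc(OC)c(OC)c(OC)c3)ccc2OC)c1`, gives 4700 nM.
Compound 3, `COc1ccc(C(=O)c2cc(OC)c(OC)c(OC)c2)cc1NC(=O)/C=C/c1ccc(C(F)(F)F)cc1`, gives 3500 nM.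

Compound 3 holds the lowest number of the three, though its step from compound 2 is a 1.3-fold lower number from compound 2 to compound 3 (0.13 log units; within the scatter), so the two are not separable. Compound 4, `COc1cc(/C=C/C(=O)Nc2cc(C(=O)c3cc(OC)c(OC)c(OC)c3)ccc2OC)ccc1F`, differs from compound 3 as follows: 4-fluoro-3-methoxyphenyl in place of 4-(trifluoromethyl)phenyl on a double-bonded chain carbon bound to a double-bonded chain carbon. The relevant measured steps are a 2.4-fold lower number from compound 1 to compound 2 (0.37 log units; beyond the scatter) and a 3.2-fold lower number from compound 1 to compound 3 (0.50 log units; beyond the scatter), both modest, showing that compound 1 sits apart while compounds 2 and 3 sit together. Compound 4 keeps the 3-methoxy pattern of compound 2 with fluorine added, so no step beyond the scatter is expected, giving an estimated 1.2-fold higher number from compound 3 to compound 4 (0.08 log units; within the scatter). Compound 4 is thus expected to give about 4200 nM in this assay, within 1500 nM to 12000 nM.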

Compound 4, half-maximal inhibitory concentration: 14100 nM
Estimate against measurement, compound 4: 3.4-fold (0.53 log units) below; measured number outside the range, above it.
By their numbers in this assay, from the lowest: compounds 3 and 2 (each within the scatter of the next); then compounds 1 and 4 (each within the scatter of the next).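

Adding a single fluoro to the 3-methoxyphenyl group of compound 2 weakens the result in this assay (a 3.0-fold higher number from compound 2 to compound 4 (0.48 log units; beyond the scatter)), so this aryl group responds to one small addition. The 4-fluoro-3-methoxyphenyl group also falls short of 4-(trifluoromethyl)phenyl (a 4.0-fold higher number from compound 3 to compound 4 (0.61 log units; beyond the scatter)), yet it cannot be told apart from 4-methoxyphenyl (a 1.3-fold higher number from compound 1 to compound 4 (0.10 log units; within the scatter)). Nothing available explains the loss.

The compounds shown leave open whether fluoro alone, without methoxy, behaves the same way. They also leave open how an amine or a carboxylic acid on this phenyl ring would fare.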